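The compounds below may be only part of what the source reports. "The series", "measured", "known", "first", "only" and "open" are said of these compounds alone.

Compound 1 `c1ccc(CCc2ccc3c(NCCCNCc4ccco4)ccnc3c2)cc1` gives 23 10^-6 cm/s in an ADME assay for permeability, using PAMPA, with a stated time of 30 min, at pH 7.4; a higher number here means that the compound crosses the layer faster, a lower number that the compound crosses the layer more slowly. Compound 2 `c1ccc(-c2ccc3c(NCCCNCc4ccco4)ccnc3c2)cc1` carries phenyl in place of phenethyl on an aromatic carbon and gives 237 10^-6 cm/s in this assay, a step of a 10-fold higher number from compound 1 to compound 2 (1.01 log units; beyond the scatter). Compound 3 `COc1ccc(F)cc1CNCCCNc1ccnc2cc(CCc3ccccc3)ccc12` differs from compound 1 by 5-fluoro-2-methoxyphenyl in place of furan-2-yl on a saturated chain carbon bound to an amine nitrogen; in this assay compound 3 gives 23 10^-6 cm/s, so no change at the digits printed from compound 1 to compound 3 (within the scatter). Compound 4 `COc1ccc(F)cc1CNCCCNc1ccnc2cc(-c3ccccc3)ccc12` is not yet measured; it differs from compound 3 by phenyl in place of phenethyl on an aromatic carbon, the same change that turns compound 1 into compound 2, while the two cores differ by 5-fluoro-2-methoxyphenyl in place of furan-2-yl on a saturated chain carbon bound to an amine nitrogen. For compound 4 a step of an 8.7-fold higher number from compound 3 to compound 4 (0.94 log units; beyond the scatter) in this assay is expected, because a 10-fold higher number from compound 1 to compound 2 (1.01 log units; beyond the scatter) shows the change on the shared core, and the core difference left the number unchanged from compound 1 to compound 3. Compound 4 is therefore estimated at 200 10^-6 cm/s in this assay, between 80 10^-6 cm/s and 400 10^-6 cm/s.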

Compound 4, apparent permeability: 237 10^-6 cm/s
The estimate for compound 4 lay 1.2-fold (0.07 log units) below the measured number; the range from low to high includes it.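

In this assay, phenyl in place of phenethyl on an aromatic carbon gives a 10-fold higher number from compound 3 to compound 4 (1.01 log units; beyond the scatter), and the step carries over between the two cores: the same change on two cores in this assay, a 10-fold higher number (1.01 log units; beyond the scatter) from compound 1 to compound 2 and a 10-fold higher number (1.01 log units; beyond the scatter) from compound 3 to compound 4, 1.0-fold (0.00 log units) apart, within the scatter of two such steps. With 5-fluoro-2-methoxyphenyl in place of furan-2-yl, the reverse view gives no change at the digits printed from compound 2 to compound 4 (within the scatter), with phenyl present as with phenethyl: the same change on two cores in this assay, no change at the digits printed (within the scatter) from compound 1 to compound 3 and no change at the digits printed (within the scatter) from compound 2 to compound 4, 1.0-fold (0.00 log units) apart, within the scatter of two such steps. Together these show the two changes acting independently across these four compounds only; they do not show that the step holds on any other core, nor why the number moves.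

The compounds shown leave open whether benzyl or a longer chain on that aromatic carbon would fit the same step. They also leave open what an amine or a carboxylic acid on the phenyl ring would do.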